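The source may hold more compounds than are shown below. What is called first, only, known or untested is meant among the compounds shown, and "the series" means these compounds.

The series is followed in an ADME assay on cells (Hepatocyte, Rattus norvegicus) for pharmacokinetics; on this read-out lower numbers stand for slow clearance and higher numbers for fast clearance. Of the compounds shown here, two have been measured. Compound 1, `O=S(=O)(c1cc(Cl)c(O)c2ncccc12)C1CCCC1`, gives 18 uL/min in this assay. Compound 2, `O=S(=O)(c1cc(F)c(O)c2ncccc12)N1CCCC1`, gives 21 uL/min in this assay. Of the two numbers, compound 2 holds the upper one, but its gap to compound 1 lies within the usual scatter of the measurement, so the two cannot be told apart on this read-out.

The next compound is compound 3, `O=S(=O)(c1cc(Cl)c(O)c2ncccc12)N1CCCC1`, not yet measured in this assay. It differs from compound 2 in one place: chloro in place of fluoro on an aromatic carbon. For the measured compounds named here, no measured pair here differs by that change alone, so no step for it is on record. Compound 1 already carries the chloro with a different group of 8 heavy atoms, and its 18 uL/min sits within the scatter of what compound 2 gives, 21 uL/min, which offers no sign that the change moves this read-out. The expected step from compound 2 to compound 3 is therefore a 1.1-fold lower number from compound 2 to compound 3 (0.02 log units; within the scatter), nothing beyond the scatter in either direction. Compound 3 is expected to give 20 uL/min in this assay, within a range of 10 uL/min to 40 uL/min.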

Compound 3, intrinsic clearance in a liver preparation (reported as CLH), per the amount of preparation that the assay uses: 14 uL/min
Compound 3: middle estimate off by 1.4-fold (0.15 log units), on the high side, within the range that was stated.
By their numbers in this assay, from the lowest: compounds 3, 1 and 2 (each within the scatter of the next).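

In this assay the change to chloro in place of fluoro on the aromatic carbon ortho to a hydroxy group now has a direct reading of a 1.5-fold lower number from compound 2 to compound 3 (0.18 log units; within the scatter) and so, on this pair, the two halogens cannot be told apart at this position. The sulfonyl substituent also has its first direct reading, since pyrrolidin-1-yl in place of cyclopentyl on a sulfonyl sulfur gives a 1.3-fold lower number from compound 1 to compound 3 (0.11 log units; within the scatter) and neither of the two places varied so far has moved this read-out beyond the scatter. Nothing at hand bears on what sets the clearance of these compounds.

The compounds shown leave open whether a group other than a halogen at the aromatic position, such as a nitrile or a methoxy group, or a sulfonyl substituent of another kind, such as morpholin-4-yl or an open-chain diethylamino group, would shift this assay beyond the scatter. Going by these compounds, each change has also been read only once, against a single partner, so it remains open whether either reading holds with the other group in a different state.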